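Pyrazole series: methoxy to hydroxy on the aryl ring

The compounds below may be only part of what the source reports. "The series", "measured", "known", "first", "only" and "open" are said of these compounds alone.

Measured so far in a functional assay on SW-620 cells (Homo sapiens) for cytotoxicity, read by sulforhodamine B assay, with a stated time of 48 h, tested at 0.001 uM; on this read-out lower numbers stand for a stronger effect and higher numbers for a weaker effect at the one concentration tested:
compound 1, `COc1cc(C)cc(-c2c(-c3ccnc(-c4ccc(C(C)=O)cc4)c3)cnn2CC#N)c1`, 96%
compound 2, `Cc1cc(O)cc(-c2nn(CC#N)cc2-c2ccnc(-c3ccc(Oc4ccccc4)cc3)c2)c1`, 93%
compound 3, `COc1cc(C)cc(-c2nn(CC#N)cc2-c2ccnc(-c3ccc(N(C)C)cc3)c2)c1`, 98%

Compound 3 gives the highest of the three numbers in this assay, but the nearest value, that of compound 1, and the furthest, that of compound 2, both lie within the usual scatter of it, so the three compounds cannot be told apart on these readings. At the concentration used, none of them shows much effect.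

Compound 4, `Cc1cc(O)cc(-c2nn(CC#N)cc2-c2ccnc(-c3ccc(N(C)C)cc3)c2)c1`, is not yet measured. It differs from compound 3 in one place: hydrogen in place of methyl on an oxygen on an aromatic ring. Compound 2 already carries the hydroxy form of this ring, with a different group on the pyridine side, and its value sits within the scatter of compound 3.

Among the compounds with values here, no measured pair isolates this change. Given how closely the three measured values sit, the step from compound 3 to compound 4 is expected to be a number 2 percentage points lower from compound 3 to compound 4 (within the scatter), that is, no change beyond the scatter in either direction. Compound 4 is therefore estimated at 96% in this assay, within a range from 86% to 104%.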

Compound 4, a percentage reported as activity, at one concentration (the size of the read-out at that concentration, not a potency): 99%
Compound 4: the middle estimate sits 3 percentage points below what was measured, within the range that was stated.
By their numbers in this assay, from the lowest: compounds 2, 1, 3 and 4 (each within the scatter of the next).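

In this assay, methoxy to hydroxy on the 3-methoxy-5-methylphenyl group now has a direct pair, and the step is a number 1 percentage points higher from compound 3 to compound 4 (within the scatter), so at this one concentration the change on this oxygen cannot be told from no change. With the hydroxy form held fixed, dimethylamino in place of phenoxy on an aromatic carbon gives a number 6 percentage points higher from compound 2 to compound 4 (within the scatter), so this second place also shows no step beyond the scatter. No supporting data bear on these readings.

Going by these compounds, all four compounds sit close together at this single low concentration, so it remains open whether the methoxy and hydroxy forms separate at higher concentrations. Also open, on these data alone, is whether a longer chain on this oxygen, such as an ethyl or a propyl group, or an amine in place of the hydroxy group, would give a step beyond the scatter.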